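A few compounds are considered here, and "the series" means these few. Any claim that something is new, unique, unknown or untested is made for them only; others in the source may bear on it.

Compounds measured so far:
compound 1 `CN1CCN(c2nc3ccccc3[nH]2)CC1` gives > 3000 nM (a limit of the assay, not a number)
compound 2 `CCCCCN1CCCN(c2nc3ccccc3n2CCOCC)CC1` gives 7.4 nM
compound 3 `CN1CCCN(c2nc3ccccc3n2CCOc2ccccc2)CC1` gives 9.1 nM

In a functional assay on ileum for inhibition of histamine H1 receptor (Cavia porcellus) (a higher number here means a weaker inhibitor, a lower number a stronger inhibitor), compound 1 stands only at a limit: its value of > 3000 nM is the limit of the assay and not a number, as the limit of > 3000 nM in this assay, at which 1 of the 3 values shown sits, records. Among the measured compounds shown here, compound 2 and compound 3, each with a substituted aromatic nitrogen and a different seven-membered ring on the shared core, give values in this assay that sit far from that limit; no single-point step links either of them to compound 1, so only their values can be compared.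

Compound 4 `COCCn1c(N2CCN(C)CC2)nc2ccccc21` is the unmeasured neighbour of compound 1. It differs from compound 1 by 2-methoxyethyl in place of hydrogen on an aromatic nitrogen. Since compound 1 shows only the limit > 3000 nM, the step is expected to run toward stronger inhibition, and well beyond the scatter; how far is uncertain, as compound 4 keeps the smaller ring of compound 1. The step expected is an at least 25-fold lower number from compound 1 to compound 4 (1.39 log units; beyond the scatter). Compound 4 is estimated at 120 nM in this assay, within a range from 20 nM to 800 nM.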

Compound 4, half-maximal inhibitory concentration: 13 nM
Beside the measured number, compound 4's estimate is 9.2-fold (0.97 log units) above it; measured number outside the range, below it.
By their numbers in this assay, from the lowest: compounds 2, 3 and 4 (each within the scatter of the next). At a limit, above all of these: compound 1.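

In this assay, among the compounds shown here, the single change of 2-methoxyethyl in place of hydrogen on the aromatic nitrogen, with the smaller ring of compound 1 kept, gives an at least 230-fold lower number from compound 1 to compound 4 (2.36 log units; beyond the scatter) and is the first step to isolate this position. Compound 1 gives > 3000 nM as a limit of the assay and not a number. On these data alone, the true size of the step therefore remains unknown, because one end of it rests on that limit: the limit of > 3000 nM in this assay, at which 1 of the 4 values shown sits.

The compounds shown leave open how much of the step depends on the ether oxygen of the chain, which a plain butyl chain on the same nitrogen would test, and whether a methyl group or a chain ending in an amine would serve as well. For the compounds shown here, they also offer no single-place step that isolates the seven-membered ring from the smaller ring.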